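Bis-benzylidene series: replacing the halogenated aryl with methoxyphenyl

The compounds below may be only part of what the source reports. "The series", "measured", "known", "first", "only" and "open" are said of these compounds alone.

Measured compounds:
compound 1 `C=CCn1c(=O)/c(=C\c2cccc(Cl)c2)[nH]c(=O)/c1=C\c1ccccc1OC`: 1200 nM
compound 2 `C=CCn1c(=O)/c(=C\c2ccccc2Cl)[nH]c(=O)/c1=C\c1ccccc1OC`: 700 nM
compound 3 `C=CCn1c(=O)/c(=C\c2cc(Br)ccc2F)[nH]c(=O)/c1=C\c1ccccc1OC`: 4700 nM

The three compounds share one core and differ only in the aryl group on a double-bonded chain carbon bound to an aromatic carbon. In a functional assay on U-937 cells (Homo sapiens) for cytotoxicity, read by CCK-8 assay, with a stated time of 72 h (a higher number here means a weaker inhibitor, a lower number a stronger inhibitor), compound 3 gives the highest number of the three. The step of a 3.9-fold higher number from compound 1 to compound 3 (0.59 log units; beyond the scatter) and the step of a 6.7-fold higher number from compound 2 to compound 3 (0.83 log units; beyond the scatter) both run beyond the scatter, whereas a 1.7-fold lower number from compound 1 to compound 2 (0.23 log units; within the scatter) does not, so compound 1 and compound 2 cannot be ordered against each other.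

Compound 4 `C=CCn1c(=O)/c(=C\c2ccccc2OC)[nH]c(=O)/c1=C\c1ccccc1OC` is not yet measured. Its change from compound 3 is 2-methoxyphenyl in place of 5-bromo-2-fluorophenyl on a double-bonded chain carbon bound to an aromatic carbon. Among the measured compounds shown here, no measured step covers the entry of a 2-methoxyphenyl at this place; the steps that bear on it are those leading into compound 3, which show the 5-bromo-2-fluorophenyl as the group with the weakest number, and removing it is expected to bring the number back toward the region of compound 1 and compound 2. Compound 4 is therefore estimated at 1200 nM in this assay, with a range of 400 nM to 3500 nM. The expected step is a 3.9-fold lower number from compound 3 to compound 4 (0.59 log units; beyond the scatter), a modest lowering.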

Compound 4, half-maximal inhibitory concentration: 5100 nM
Beside the measured number, compound 4's estimate is 4.3-fold (0.63 log units) below it; the whole stated range lies below it.
By their numbers in this assay, from the lowest: compounds 2 and 1 (each within the scatter of the next); then compounds 3 and 4 (each within the scatter of the next).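

In this assay the entry of 2-methoxyphenyl on a double-bonded chain carbon bound to an aromatic carbon leaves the number in the region of compound 3 (a 1.1-fold higher number from compound 3 to compound 4 (0.04 log units; within the scatter)), so 2-methoxyphenyl and 5-bromo-2-fluorophenyl cannot be ordered at this place. The chlorophenyl compounds stand lower, both for methoxy in place of chloro on an aromatic carbon (a 7.3-fold higher number from compound 2 to compound 4 (0.86 log units; beyond the scatter)) and for 2-methoxyphenyl in place of 3-chlorophenyl (a 4.3-fold higher number from compound 1 to compound 4 (0.63 log units; beyond the scatter)). The high number is therefore not confined to the bromine and fluorine pair of compound 3, since a group carrying neither halogen gives a number within the scatter of it.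

Nothing at hand bears on why chloro and methoxy differ here. Open, from the compounds shown here alone, is whether an amine or a carboxylic acid on this aryl group would keep the lower numbers of compound 1 and compound 2.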